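Swapping the benzylamine for a dichlorophenyl thioether

This account rests on a few compounds, and the source may have more. Where it says the series, first, only, none or still open, it means among the compounds named here.

Among the three compounds measured so far, compound 3 `Nc1cc(N)c2nc(-c3ccccc3)c(NCc3ccc(F)cc3)nc2c1` stands at the strongest end. In a functional assay on SF-539 cells (Homo sapiens) for inhibition, read by sulforhodamine B assay, with a stated time of 48 h (on this read-out lower numbers stand for stronger inhibition of growth and higher numbers for weaker inhibition of growth), compound 3 gives 3550 nM, compound 1 `Nc1cc(N)c2nc(-c3ccccc3)c(NCc3ccc(Cl)c(Cl)c3)nc2c1` gives 18600 nM, and compound 2 `COc1ccc(CNc2nc3cc(N)cc(N)c3nc2-c2ccccc2)cc1OC` gives 45700 nM. The step of a 5.2-fold lower number from compound 1 to compound 3 (0.72 log units; beyond the scatter) separates compound 3 from its nearest neighbour, and the step of a 13-fold lower number from compound 2 to compound 3 (1.11 log units; beyond the scatter) separates it from the furthest.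

Compound 4 `Nc1cc(N)c2nc(-c3ccccc3)c(Sc3ccc(Cl)c(Cl)c3)nc2c1` differs from compound 3 in one place: (3,4-dichlorophenyl)sulfanyl in place of (4-fluorobenzyl)amino on an aromatic carbon. Within the data shown here, of the measured steps, only the one from compound 1 to compound 3 touches this change, since it also swaps a 3,4-dichlorophenyl for a 4-fluorophenyl on the same side chain, and a 5.2-fold lower number from compound 1 to compound 3 (0.72 log units; beyond the scatter) was the result. Read in reverse, returning to the dichlorinated ring points to a higher number. Among the measured compounds shown here, no measured pair shows what replacing the aminomethylene linker with a sulfur atom does, so that part of the change is uncharted. The expectation for compound 4 in this assay is therefore a step of roughly a 4.2-fold higher number from compound 3 to compound 4 (0.63 log units; beyond the scatter), upward, beyond the scatter. Compound 4 is estimated at 15000 nM, within a range from 4000 nM to 60000 nM.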

Compound 4, concentration for total growth inhibition: 41700 nM
Compound 4: the middle estimate sits 2.8-fold (0.44 log units) below what was measured; the range from low to high includes it.
By their numbers in this assay, from the lowest: compound 3; then compound 1; then compounds 4 and 2 (each within the scatter of the next).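

In this assay, the step of a 12-fold higher number from compound 3 to compound 4 (1.07 log units; beyond the scatter) shows that this aromatic carbon does not tolerate every group of the same size: (3,4-dichlorophenyl)sulfanyl and (4-fluorobenzyl)amino both hold 9 heavy atoms, yet the swap is large and moves toward weaker inhibition of growth. The earlier compounds shown here all kept the same nitrogen-linked benzyl chain, whereas compound 1 and compound 4 carry the same dichlorinated ring on different links, and compound 1 gives 18600 nM while compound 4 gives 41700 nM, the higher number on the sulfur link. The step also changes the hydrogen-bond donor count from 1 to 0, but nothing measured here explains why the number rises.

The step from compound 3 changes the link and the ring together, so a compound bearing (4-fluorophenyl)sulfanyl would be needed to show how much of the change belongs to each. From the compounds shown here alone, whether the loss is particular to sulfur also stays open, and a phenoxy group, with an oxygen atom as the link, would test that.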